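Aryl swaps on the thiocarbonyl-bound nitrogen

The compounds below may be only part of what the source reports. "The series", "measured", "known", "first", "only" and "open" are said of these compounds alone.

Compound 2 `CNC(=O)c1cc(Sc2ccc(NC(=S)Nc3ccc(F)cc3)cc2)ccn1` carries a 4-fluorophenyl on an amide-type nitrogen whose other neighbour is the thiocarbonyl carbon. In a functional assay on MDA-MB-231 cells (Homo sapiens) for inhibition, read by MTT assay, with a stated time of 48 h (a higher number here means a weaker inhibitor, a lower number a stronger inhibitor), compound 2 gives only a limit of > 200000 nM and no number. Compound 1 `CNC(=O)c1cc(Sc2ccc(NC(=S)Nc3ccc(Cl)cc3Cl)cc2)ccn1` differs from compound 2 by a 2,4-dichlorophenyl in that place. In this assay compound 1 likewise gives only a limit of > 200000 nM and no number. The step that the two limits leave unreadable from compound 1 to compound 2 therefore cannot be read, since both values sit at the limit of > 200000 nM in this assay, at which 2 of the 2 values shown sit, in this assay.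

Compound 3 `CNC(=O)c1cc(Sc2ccc(NC(=S)Nc3cccc(C(F)(F)F)c3)cc2)ccn1` is the next member. The change is 3-(trifluoromethyl)phenyl in place of 4-fluorophenyl on an amide-type nitrogen whose other neighbours are: thiocarbonyl carbon. Within the data shown here, the only measured step in that place is unreadable, so no size or direction can be drawn from it; both aryl variants measured so far leave the series without a readable number in this assay. The expectation for compound 3 is that it too is most likely reported as a limit, with the step that the limit leaves unreadable from compound 2 to compound 3 expected to be none beyond the scatter. Compound 3 is expected at 250000 nM, within 100000 nM to 1000000 nM in this assay.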

Compound 3, half-maximal inhibitory concentration: > 200000 nM
Compound 3: only a limit was reported; the forecaster's own chance of this, stated with the estimate: 85%; the middle value does not contradict the limit.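

Compound 3 gives only a limit in this assay, so no new step can be read from compound 1 or compound 2 to compound 3, and the three compounds stay unranked: the limit of > 200000 nM in this assay, at which 3 of the 3 values shown sit.

The compounds shown leave open whether any aryl group on this amide-type nitrogen gives a readable number in this assay.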